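Oral bioavailability notes: fluoro on the compound 3 aryl ring

The compounds below may be only part of what the source reports. "The series", "measured", "known", "first", "only" and "open" are said of these compounds alone.

Measured in an ADME assay on the whole organism (Rattus norvegicus, strain Sprague-Dawley) for pharmacokinetics, using cassette dosing, at a dose of 1 mg/kg by the oral route; on this read-out higher numbers stand for higher oral bioavailability and lower numbers for lower oral bioavailability:
- compound 1 `O=C(Nc1ccc2[nH]c(=O)oc2c1)C(=O)N1CCN(c2ccc(Cl)cc2)CC1`: 17.8%
- compound 2 `O=C(Nc1ccc2[nH]c(=O)oc2c1)C(=O)N1CCN(c2ccc(C(F)(F)F)cc2)CC1`: 24.8%
- compound 3 `C[C@@H]1CN(C(=O)C(=O)Nc2ccc3[nH]c(=O)oc3c2)CCN1c1ccc(Cl)cc1`: 52.6%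

Compound 3 stands highest of the three at 52.6%. Compound 4 `C[C@@H]1CN(C(=O)C(=O)Nc2ccc3[nH]c(=O)oc3c2)CCN1c1ccc(Cl)c(F)c1` differs from it by fluoro in place of hydrogen on an aromatic carbon, with fluoro in place of hydrogen on an aromatic carbon, ortho to a chloro group. Among the compounds with values here, no measured step introduces a fluoro. The nearest guide is trifluoromethyl in place of chloro on an aromatic carbon, which gave a number 7 percentage points higher from compound 1 to compound 2 (within the scatter). Methyl in place of hydrogen on a saturated ring carbon gave a number 34.8 percentage points higher from compound 1 to compound 3 (beyond the scatter), but compound 4 keeps that methyl, so this large step is not expected to recur. The expected change is small and of uncertain direction, with nothing beyond the scatter: a number 2.6 percentage points lower from compound 3 to compound 4 (within the scatter). For compound 4 the estimated value is 50%, with an expected range of 32% to 68%.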

Compound 4, oral bioavailability: 32%
Compound 4: middle estimate off by 18 percentage points, on the high side; the range from low to high includes it.
By their numbers in this assay, from the lowest: compounds 1, 2 and 4 (each within the scatter of the next, the first and the last beyond it); then compound 3.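

In this assay, fluoro in place of hydrogen on an aromatic carbon, ortho to a chloro group, gives a number 20.6 percentage points lower from compound 3 to compound 4 (beyond the scatter) on a change of one heavy atom. The 4-chlorophenyl ring therefore tolerates change less freely with the methyl present than a number 7 percentage points higher from compound 1 to compound 2 (within the scatter) alone suggested, though that earlier step changed a different place and lacked the methyl. Nothing measured here accounts for the fall.

Open, as far as these compounds go, is whether the loss belongs to fluoro or to this place on the ring. A nitrile or a methoxy on the same carbon would help separate the two, as would fluoro on the series without the methyl.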